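Notes on an aryl ether variant of compound 1

The source may hold more compounds than are shown below. What is called first, only, known or untested is meant among the compounds shown, and "the series" means these compounds.

Compound 1 `Cc1ccc(NC(=O)c2cccc(C(F)(F)F)c2)cc1N1Cc2cnc(Nc3ccc(C)c(C(F)(F)F)c3)nc2N(C)C1=O` is known in an ADME assay on BaF3 cells (Mus musculus) for antiproliferative activity, read by CellTiter-Glo and CCK-8 assay, with a stated time of 72 h (a higher number here means a weaker inhibitor of growth, a lower number a stronger inhibitor of growth), only as a limit: compound 1 gives > 10000 nM. Compound 2 `Cc1ccc(Nc2ncc3c(n2)N(C)C(=O)N(c2cc(NC(=O)c4cccc(-c5ccccc5)c4)ccc2C)C3)cc1N` also sits at a limit, giving > 10000 nM. Compound 3 `Cc1cccc(C(=O)Nc2ccc(C)c(N3Cc4cnc(Nc5ccc(C)c(N)c5)nc4N(C)C3=O)c2)c1` likewise reports only a limit, > 10000 nM. Going by the values given here, the one measured step, a step that the two limits leave unreadable from compound 2 to compound 3, therefore cannot be read, and all three values share (the limit of > 10000 nM in this assay, at which 3 of the 3 values shown sit). Compound 4 `Cc1ccc(Oc2ncc3c(n2)N(C)C(=O)N(c2cc(NC(=O)c4cccc(C(F)(F)F)c4)ccc2C)C3)cc1N` differs from compound 1 by 3-amino-4-methylphenoxy in place of (4-methyl-3-(trifluoromethyl)phenyl)amino on an aromatic carbon. Among the compounds with values here, no measured step touches this change, so nothing sets its size or direction. With every value sitting at the limit, compound 4 is expected to remain near it, the step of a number no higher from compound 1 to compound 4 (the limit leaves the size open) being an estimate with no readable direction. Compound 4 is thus estimated at 10000 nM, between 3000 nM and 30000 nM.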

Compound 4, concentration for 50% growth inhibition: > 10000 nM
Compound 4 was reported as a limit (the forecaster's own chance of this, stated with the estimate: 70%); the middle value lies on the limit itself.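

Going by these compounds alone, compound 1 and compound 4 both report only a limit, so no step between them can be read: the limit of > 10000 nM in this assay, at which 4 of the 4 values shown sit. The compounds shown leave open which change, if any, would give a measured number rather than a limit.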